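This account rests on a few compounds, and the source may have more. Where it says the series, first, only, none or still open, it means among the compounds named here.

For the measured compounds named here, in a functional assay on HepG2 cells (Homo sapiens) for cytotoxicity, read by MTT assay, with a stated time of 24 h (a lower number here means a stronger inhibitor, a higher number a weaker inhibitor), compound 1 (`O=C1/C(=C/c2ccncc2)CNC/C1=C\c1ccccc1F`) gives 8200 nM and compound 2 (`O=C1/C(=C/c2ccncc2)CNC/C1=C\c1ccccc1C(F)(F)F`) gives 6130 nM and so stands within the scatter of compound 1, the only other compound measured. Compound 3 (`O=C1/C(=C/c2ccncc2)CN(S(=O)(=O)c2ccc(F)cc2)C/C1=C\c1ccccc1C(F)(F)F`) differs from compound 2 by a single change ((4-fluorophenyl)sulfonyl in place of hydrogen on an amine nitrogen in a ring), namely (4-fluorophenyl)sulfonyl in place of hydrogen on an amine nitrogen in a ring. Going by the values given here, the one measured step (a 1.3-fold lower number from compound 1 to compound 2 (0.13 log units; within the scatter)) is a swap on an aromatic carbon, so it bears only loosely on this change, and no measured compound carries any group on that nitrogen. Among the compounds with values here, with only that step as a guide and a far larger group entering here, a modest move toward a lower number in this assay is expected, though with little certainty. The estimated change is a 2.2-fold lower number from compound 2 to compound 3 (0.34 log units; beyond the scatter) and could prove smaller. Compound 3 is estimated at 2800 nM with a likely range from 800 nM to 10000 nM.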

Compound 3, half-maximal inhibitory concentration: 4010 nM
Compound 3: the middle estimate sits 1.4-fold (0.16 log units) below what was measured, and the stated range covers the measured number.
By their numbers in this assay, from the lowest: compounds 3, 2 and 1 (each within the scatter of the next, the first and the last beyond it).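

In this assay, placing (4-fluorophenyl)sulfonyl on the amine nitrogen in the ring gives a 1.5-fold lower number from compound 2 to compound 3 (0.18 log units; within the scatter). For the compounds shown here, this is the first look at this nitrogen carrying anything other than hydrogen, and it shows that a large group with its own aromatic ring can sit there without the number moving beyond the usual scatter. No information at hand explains why the number holds for such a large addition.

Going by these compounds alone, with only one group on this nitrogen, it remains open whether the sulfonyl link, the aromatic ring or the fluorine matters for the reading. A smaller methylsulfonyl, an acetyl amide, a benzyl group or a plain phenylsulfonyl at the same nitrogen would help separate these parts.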